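Cytotoxicity notes: side-chain swap from compound 2 to compound 3

The compounds below may be only part of what the source reports. "The series", "measured", "known", "first", "only" and "open" are said of these compounds alone.

Measured so far:
compound 1 `NCCNc1cc(N2CCc3ccccc3C2)nc2ccccc12`: 15000 nM
compound 2 `CNCCNc1cc(N2CCCc3ccc(F)cc3C2)nc2ccc(C)cc12`: 29000 nM

In an ADME assay on HEp-2 cells (Homo sapiens) for cytotoxicity, read by CCK-8 assay, with a stated time of 5 days (on this read-out higher numbers stand for lower toxicity in this test and lower numbers for higher toxicity in this test), compound 2 gives 29000 nM, the higher of the two numbers, though compound 1 at 15000 nM sits within the scatter of it. Compound 3 `Cc1ccc2nc(N3CCCc4ccc(F)cc4C3)cc(NCC(N)=O)c2c1` differs from compound 2 by carbamoyl in place of (methylamino)methyl on a saturated chain carbon bound to a nitrogen on an aromatic ring. For the measured compounds named here, no step between measured compounds is available for this change, so the expectation rests on compound 2 alone. A small upward step, at or just beyond the scatter, is expected from compound 2 to compound 3: a 1.3-fold higher number from compound 2 to compound 3 (0.12 log units; within the scatter). Compound 3 is therefore expected to give 38000 nM, within a range of 15000 nM to 90000 nM.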

Compound 3, half-maximal cytotoxic concentration: 22000 nM
Estimate against measurement, compound 3: 1.7-fold (0.24 log units) above, and the stated range covers the measured number.
By their numbers in this assay, from the lowest: compounds 1, 3 and 2 (each within the scatter of the next).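

In this assay carbamoyl in place of (methylamino)methyl on a saturated chain carbon bound to a nitrogen on an aromatic ring gives a 1.3-fold lower number from compound 2 to compound 3 (0.12 log units; within the scatter) as the first step read at this position. The (methylamino)methyl group can therefore be replaced here by carbamoyl, with the same count of heavy atoms, without a step beyond the scatter. No measured property on hand accounts for this result.

On these data alone, whether a carboxylic acid or a longer chain bearing an amine at this place would give a step beyond the scatter remains open. As far as these compounds go, whether carbamoyl gives a similar step on the core of compound 1 also remains open.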